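A Shorter Side Group on the Shared Core

This account rests on a few compounds, and the source may have more. Where it says the series, first, only, none or still open, it means among the compounds named here.

Three measured compounds share one core and differ only in the side group attached through a saturated chain carbon to a saturated ring carbon. Compound 1 `CN(CCC#N)C[C@H]1CN(c2ccc(-n3cc(-c4ccccn4)cn3)c(F)c2)C(=O)O1` carries a (2-cyanoethyl)(methyl)amino group there. In an ADME assay on HEK293-A cells (Homo sapiens) for cytotoxicity, read by MTT assay, with a stated time of 48 h (a lower number here means a stronger inhibitor, a higher number a weaker inhibitor), compound 1 gives > 400 ug/mL, a limit of the assay rather than a number. Compound 2 `O=C1O[C@@H](Cn2ccnn2)CN1c1ccc(-n2cc(-c3ccccn3)cn2)c(F)c1` carries a 1H-1,2,3-triazol-1-yl group instead, and in this assay compound 2 gives 225 ug/mL. Compound 3 `O=CNC[C@H]1CN(c2ccc(-n3cc(-c4ccccn4)cn3)c(F)c2)C(=O)O1` carries a formylamino group, and in this assay compound 3 gives > 400 ug/mL, again a limit of the assay. Compound 3 thus stands at the limit of > 400 ug/mL in this assay, at which 2 of the 3 values shown sit. The measured steps are all modest: an at least 1.7-fold lower number from compound 1 to compound 2 (0.24 log units; that floor lies within the scatter), an at least 1.7-fold higher number from compound 2 to compound 3 (0.24 log units; that floor lies within the scatter), and a step that the two limits leave unreadable from compound 1 to compound 3. Compound 4 `NC(=O)[C@H]1CN(c2ccc(-n3cc(-c4ccccn4)cn3)c(F)c2)C(=O)O1` has not yet been measured; its change is carbamoyl in place of (formylamino)methyl on a saturated ring carbon. Among the measured compounds shown here, no measured step shows this exact change, and none of the measured changes in that side group gave a step readable beyond the scatter, so compound 4 is expected to stay close to the limit, with an expected step of a number no higher from compound 3 to compound 4 (the limit leaves the size open). In this assay compound 4 is estimated at 400 ug/mL, between 200 ug/mL and 800 ug/mL.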

Compound 4, half-maximal inhibitory concentration: 152 ug/mL
Estimate against measurement, compound 4: 2.6-fold (0.42 log units) above, outside the stated range (below it).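

Carbamoyl in place of (formylamino)methyl is the first change at this position to give a step readable beyond the scatter, an at least 2.6-fold lower number from compound 3 to compound 4 (0.42 log units; beyond the scatter), and carbamoyl in place of ((2-cyanoethyl)(methyl)amino)methyl gives an at least 2.6-fold lower number from compound 1 to compound 4 (0.42 log units; beyond the scatter). Carbamoyl in place of (1H-1,2,3-triazol-1-yl)methyl gives a 1.5-fold lower number from compound 2 to compound 4 (0.17 log units; within the scatter), so that pair cannot be told apart. Both readable steps start from a limit of the assay, which leaves their full size unknown: the limit of > 400 ug/mL in this assay, at which 2 of the 4 values shown sit.

On these data alone, whether the lower number goes with the carbamoyl group itself or with a side group that reaches less far from the ring stays open. A carbamoyl on a longer chain, or a carboxylic acid on the same saturated ring carbon, would help to separate the two.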